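A few compounds are considered here, and "the series" means these few. Any claim that something is new, unique, unknown or untested is made for them only; others in the source may bear on it.

Two compounds of a shared core have been run through an ADME assay on microsomes from liver (Homo sapiens) for metabolic stability, read by LC-MS, using NADPH, with a stated time of 30 min, tested at 0.5 uM; a lower number here means slower removal, a higher number faster removal of the compound. Compound 1, `OCc1ccc(Oc2ccc(N3CCC4(CC3)OCCc3sccc34)cc2)cc1`, carries a substituted aromatic ether on the basic nitrogen of that core; in this assay compound 1 gives 1.9 mL/min/g. Compound 2, `Cn1cc(CN2CCC3(CC2)OCCc2sccc23)c2ccccc21`, instead carries a methylated fused bicyclic group linked through a single carbon; in this assay compound 2 gives 4.5 mL/min/g. Among the two numbers, compound 2 stands at the higher end, and its gap to compound 1 lies beyond the usual scatter, so compound 2 is removed faster in this preparation.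

Compound 3, `c1ccc2c(CN3CCC4(CC3)OCCc3sccc34)c[nH]c2c1`, is not yet measured. Compared with compound 2, the change is hydrogen in place of methyl on an aromatic nitrogen. For the measured compounds named here, no measured pair shows this exact change, so the expectation has to rest on the value of compound 2, 4.5 mL/min/g, and the small size of the change. The step of a 1.4-fold lower number from compound 2 to compound 3 (0.15 log units; within the scatter) is expected to be modest, leaning toward slower removal, and may well stay within the scatter. For compound 3 in this assay the estimate is 3.2 mL/min/g, within a range from 1.6 mL/min/g to 6.5 mL/min/g.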

Compound 3, intrinsic clearance in a liver preparation (reported as CLH), per the amount of preparation that the assay uses: 3.1 mL/min/g
Compound 3: the middle estimate sits 1.0-fold (0.01 log units) above what was measured; the measured number falls inside the stated range.
By their numbers in this assay, from the lowest: compounds 1, 3 and 2 (each within the scatter of the next, the first and the last beyond it).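

In this assay, putting hydrogen in place of methyl on the aromatic nitrogen of the five-membered aromatic ring gives a 1.5-fold lower number from compound 2 to compound 3 (0.16 log units; within the scatter) and so leaves the two compounds indistinguishable in this test, since a gap of this size could also arise between repeat measurements of a single compound. For the compounds shown here, this is the first pair here that differs in one place only, and it shows that this small change, on this one nitrogen, does not clearly alter how fast the compound is removed, whether the nitrogen carries the methyl or just a hydrogen. Nothing available here speaks to what lies behind this result.

A single pair says little about this position as a whole, and a larger group on the same nitrogen, such as an ethyl group, a longer chain or an acetyl group, might behave quite differently from methyl. As far as these compounds go, it also remains open whether a group with a carboxylic acid or an amine at this position would shift the removal rate clearly beyond the scatter.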